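This account rests on a few compounds, and the source may have more. Where it says the series, first, only, none or still open, it means among the compounds named here.

In a functional assay on HCT-116 cells (Homo sapiens) for inhibition, read by CCK-8 assay, with a stated time of 48 h (on this read-out higher numbers stand for weaker inhibition and lower numbers for stronger inhibition), compound 1 (`COc1cc(-c2cc3nccc(-c4cc(OC)c(OC)c(OC)c4)n3n2)cc(OC)c1OC`) gives > 10000 nM as a limit of the assay, not a number. Compound 2 (`COc1cc(-c2ccnc3cc(-c4c[nH]c5ccccc45)nn23)cc(OC)c1OC`) stands lowest at 35 nM and compound 3 (`Cn1ccc2cc(-c3cc4nccc(-c5ccc(F)cc5)n4n3)ccc21`) gives 2160 nM here, a gap beyond the scatter. Compound 4 (`COc1cc(-c2ccnc3cc(-c4ccc5c(ccn5C)c4)nn23)cc(OC)c1OC`) differs from compound 2 in one group on an aromatic carbon (1-methyl-1H-indol-5-yl in place of 1H-indol-3-yl on an aromatic carbon). Within the data shown here, no measured step covers this change. Compound 2 at 35 nM remains the anchor, while compound 3, which holds the entering 1-methyl-1H-indol-5-yl group alongside other substituents, sits at 2160 nM in this series, so a modest rise towards weaker inhibition is expected. The expected change is a 2.3-fold higher number from compound 2 to compound 4 (0.36 log units; beyond the scatter) in this assay, slightly beyond the scatter. The estimated value for compound 4 is 80 nM within an expected range of 15 nM to 500 nM on this read-out.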

Compound 4, half-maximal inhibitory concentration: 39 nM
Estimate against measurement, compound 4: 2.1-fold (0.31 log units) above, within the range that was stated.
By their numbers in this assay, from the lowest: compounds 2 and 4 (each within the scatter of the next); then compound 3. At a limit, above all of these: compound 1.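

In this assay, the step of a 1.1-fold higher number from compound 2 to compound 4 (0.05 log units; within the scatter) shows that this position, on an aromatic carbon of a five-membered aromatic ring with 2 nitrogen, accepts 1-methyl-1H-indol-5-yl in place of 1H-indol-3-yl without a change beyond the scatter. The hydrogen-bond donor counted in 1H-indol-3-yl is therefore not required here for this read-out. Nothing measured here accounts for this step.

Still open, on these data alone, is how a non-aromatic group at this position, such as a morpholine or a simple amine, would read in this assay.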